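Amine substituent survey on the shared core

The source may hold more compounds than are shown below. What is called first, only, known or untested is meant among the compounds shown, and "the series" means these compounds.

Measured so far in an assay on a protein complex for inhibition of ubiquitin carboxyl-terminal hydrolase 1/WD repeat-containing protein 48 (Homo sapiens), read by fluorescence; a higher number here means a weaker inhibitor, a lower number a stronger inhibitor:
compound 1, `Cc1ccc(CNc2nc(-c3ccccc3C(F)(F)F)nc3ccccc23)s1`: 5100 nM
compound 2, `COc1ccc(CNc2nc(-c3ccccc3C(F)(F)F)nc3ccccc23)cc1`: 6200 nM
compound 3, `FC(F)(F)c1ccccc1-c1nc(NCC#Cc2cccnc2)c2ccccc2n1`: 8900 nM

Compound 2 holds the second highest of the three numbers in this assay. Its nearest neighbour is compound 1, separated by a 1.2-fold higher number from compound 1 to compound 2 (0.08 log units; within the scatter); its furthest is compound 3, separated by a 1.4-fold higher number from compound 2 to compound 3 (0.16 log units; within the scatter). Both of these steps, and also a 1.7-fold higher number from compound 1 to compound 3 (0.24 log units; within the scatter), sit within the scatter, so the three measured variations at the carbon bound to the ring nitrogen read as flat.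

Compound 4, `FC(F)(F)c1ccccc1-c1nc(NCc2ccc(-c3ccccc3)cc2)c2ccccc2n1`, differs from compound 2 by phenyl in place of methoxy on an aromatic carbon. The three measured steps all bear on this position in the loose sense that they exchange the group on the same chain carbon, and none of them moved the number beyond the scatter. Within the data shown here, a change of phenyl for methoxy on the aromatic carbon of compound 2 has no measured counterpart, so the expectation rests on that flatness alone.

Compound 4 is therefore expected to give 5500 nM in this assay, within 2500 nM to 12000 nM. The step this estimate implies, a 1.1-fold lower number from compound 2 to compound 4 (0.05 log units; within the scatter), is expected to stay within the scatter.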

Compound 4, half-maximal inhibitory concentration: 3700 nM
Estimate against measurement, compound 4: 1.5-fold (0.17 log units) above, and the stated range covers the measured number.
By their numbers in this assay, from the lowest: compounds 4, 1, 2 and 3 (each within the scatter of the next, the first and the last beyond it).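

In this assay, phenyl in place of methoxy on an aromatic carbon, para to a large group, gives a 1.7-fold lower number from compound 2 to compound 4 (0.22 log units; within the scatter) and so stays as flat as the earlier exchanges on the chain carbon. Those exchanges replaced the whole group on that carbon, whereas this change keeps the six-membered aromatic ring of compound 2 and alters only its substituent. Here a hydrogen-bond acceptor leaves and a six-membered aromatic ring of carbon only enters, with no step beyond the scatter. Nothing available accounts for why the number holds across this change.

Open, on these data alone, is whether an amine or a carboxylic acid on this aromatic carbon would move the number beyond the scatter. Also open, as far as these compounds go, is how far the number depends on the trifluoromethyl group, which all four compounds carry.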